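Swapping chloro for methylamino on an acyclic guanine analog

The source may report more compounds than this note shows. Statements on the series, on what has been measured and on what is new or still open speak of the compounds shown alone.

Of the compounds shown here, three have been tested in a functional assay on L1210 cells (Mus musculus) for inhibition; a lower number here means a stronger inhibitor, a higher number a weaker inhibitor. Compound 1 `Cc1cn(COCCO)c(=O)[nH]c1=O` reaches only a limit of the assay, > 1000 ug/mL. Compound 2 `CN(C)c1ncnc2c1ncn2COCCO` likewise reaches only a limit, > 500 ug/mL. For the measured compounds named here, compound 3 `Nc1nc2c(nc(Cl)n2COCCO)c(=O)[nH]1` is the single compound with a real number, 350 ug/mL, so it alone gives a foothold among the values shown. Compound 4 `CNc1nc2c(=O)[nH]c(N)nc2n1COCCO` has not been measured. It differs from compound 3 in one place: methylamino in place of chloro on an aromatic carbon. Going by the values given here, no measured pair shows a step of this kind, so its size is uncertain. The step is expected to be a 1.4-fold higher number from compound 3 to compound 4 (0.15 log units; within the scatter), a modest weakening that may not rise beyond the scatter. Compound 4 is therefore expected to give 500 ug/mL, somewhere between 150 ug/mL and 1500 ug/mL.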

Compound 4, concentration for 50% inhibition: > 500 ug/mL
Compound 4 ended at the assay's limit; the forecaster's own chance of this, stated with the estimate: 50%; the middle value sits exactly at the limit.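

In this assay compound 4 gives > 500 ug/mL, which is a limit and not a number. Methylamino in place of chloro at this position gives an at least 1.4-fold higher number from compound 3 to compound 4 (0.15 log units; that floor lies within the scatter), so this change shows no sign of stronger inhibition, and only a floor for the step can be read. That floor is set by where the assay stops: the limit of > 500 ug/mL in this assay, at which 2 of the 4 values shown sit.

From the compounds shown here alone, the true size of the step remains open. Also open, going by these compounds, is whether a different group on this carbon, such as bromo or a plain amino group, would give a real number.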